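Methoxy in place of chloro on the 3-chlorophenyl group

The source may hold more compounds than are shown below. What is called first, only, known or untested is meant among the compounds shown, and "the series" means these compounds.

Of the compounds shown here, two with a shared core have been measured so far. In a functional assay on MCF7 cells (Homo sapiens) for cytotoxicity, read by MTT assay, with a stated time of 72 h (a higher number here means a weaker inhibitor, a lower number a stronger inhibitor), compound 1 (`O=C1C(=Cc2ccc(O)cc2)C(=O)N(c2ccc(Cl)cc2)N1c1ccc(Cl)cc1`) gives 23200 nM and compound 2 (`O=C1C(=Cc2cccc(Cl)c2)C(=O)N(c2ccc(Cl)cc2)N1c1ccc(Cl)cc1`) gives 18300 nM as its value. Those two numbers lie within the scatter of each other, so compound 2 stands level with compound 1 and no order can be read between them.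

Compound 3 (`COc1cccc(C=C2C(=O)N(c3ccc(Cl)cc3)N(c3ccc(Cl)cc3)C2=O)c1`) keeps the core of compound 2 and carries methoxy in place of chloro on an aromatic carbon, meta to a large group (methoxy in place of chloro on an aromatic carbon). For the measured compounds named here, only one measured step bears on this change. That step, a 1.3-fold lower number from compound 1 to compound 2 (0.10 log units; within the scatter) as 3-chlorophenyl replaces 4-hydroxyphenyl, shows little movement for a change on the same aromatic ring. Going by the values given here, no measured compound yet shows what a methoxy group does here, so the evidence is thin. In this assay no step beyond the scatter is expected, and no direction can be favoured. The expected move is a 1.1-fold higher number from compound 2 to compound 3 (0.04 log units; within the scatter) and it remains only an estimate. Compound 3 is estimated at 20000 nM with 10000 nM as the lower end and 40000 nM as the upper end of the expected range.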

Compound 3, half-maximal inhibitory concentration: 18100 nM
For compound 3 the middle estimate is 1.1-fold (0.04 log units) above the measured one; measured number inside the range.
By their numbers in this assay, from the lowest: compounds 3, 2 and 1 (each within the scatter of the next).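

In this assay the exchange of chloro for methoxy on the aromatic carbon gives no measurable shift (a 1.0-fold lower number from compound 2 to compound 3 (0.00 log units; within the scatter)), so at this place the only methoxy group shown and the chloro group cannot be told apart, although methoxy brings oxygen and one hydrogen-bond acceptor that chloro lacks. The step from the 4-hydroxyphenyl group to the 3-methoxyphenyl group is just as small (a 1.3-fold lower number from compound 1 to compound 3 (0.11 log units; within the scatter)), which means that 4-hydroxyphenyl, 3-chlorophenyl and 3-methoxyphenyl all stand level in this series, and no order can be read among compounds 1, 2 and 3. Nothing among the data shown offers an explanation for this flat picture.

The three compounds leave open whether any group on this aromatic ring can move the number beyond the scatter at all, since each one shown remains within it of the others. An amine, a carboxylic acid or a longer chain such as ethoxy in the same place would test this, and the effect of changes elsewhere on the shared core remains equally unknown.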